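Fluorophenyl Position Shift on an Aryl Amide Series

The source may report more compounds than this note shows. Statements on the series, on what has been measured and on what is new or still open speak of the compounds shown alone.

Compound 1 `CNC(=O)c1cc(Oc2ccc(NC(=O)c3nn(-c4ccc(C)cc4)c(=O)cc3C)cc2F)ccn1` gives 10600 nM in a functional assay on HepG2 cells (Homo sapiens) for cytotoxicity, read by MTT assay, with a stated time of 72 h; on this read-out lower numbers stand for stronger inhibition and higher numbers for weaker inhibition.
Compound 2 `Cc1cc(=O)n(-c2ccccc2C(F)(F)F)nc1C(=O)Nc1ccc(Oc2ncnc3ccsc23)cc1` gives 9230 nM.
Compound 3 `Cc1cc(=O)n(-c2cccc(F)c2)nc1C(=O)Nc1ccc(Oc2ncnc3ccsc23)cc1` gives 10200 nM.

Compound 3 holds the second highest of the three numbers; compound 1 sits nearest and compound 2 furthest, and both gaps fall within the scatter. Compound 4 `Cc1cc(=O)n(-c2ccc(F)cc2)nc1C(=O)Nc1ccc(Oc2ncnc3ccsc23)cc1` differs from compound 3 by 4-fluorophenyl in place of 3-fluorophenyl on an aromatic nitrogen. Going by the values given here, the one measured step at this position, a 1.1-fold higher number from compound 2 to compound 3 (0.04 log units; within the scatter), was within the scatter, and no measured pair shows the fluorine moved within the ring. With the three numbers all close together, no step beyond the scatter is expected for this change, so compound 4 is expected to give 10000 nM, with a range from 4000 nM to 25000 nM. The expected step, a 1.0-fold lower number from compound 3 to compound 4 (0.01 log units; within the scatter), is thus essentially none.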

Compound 4, half-maximal inhibitory concentration: 2110 nM
Estimate against measurement, compound 4: 4.7-fold (0.68 log units) above; measured number below the stated range.
By their numbers in this assay, from the lowest: compound 4; then compounds 2, 3 and 1 (each within the scatter of the next).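

In this assay, the position on the aromatic nitrogen proves sensitive to where the fluorine sits: 4-fluorophenyl in place of 3-fluorophenyl gives a 4.8-fold lower number from compound 3 to compound 4 (0.68 log units; beyond the scatter) although the two groups have the same atoms. Going by these compounds alone, the 4-fluorophenyl group also stands apart from 2-(trifluoromethyl)phenyl, with a 4.4-fold lower number from compound 2 to compound 4 (0.64 log units; beyond the scatter) as the first steps here to lie beyond the scatter. No evidence is available to explain this shift. Still open, going by these compounds, is whether an amine or a methoxy group in place of the fluorine would keep the lower number.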